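The source may report more compounds than this note shows. Statements on the series, on what has been measured and on what is new or still open speak of the compounds shown alone.

Compound 1 `CC(C)c1cccc(C(C)C)c1NC(=O)NCC1(c2ccc(C(C)(C)C)cc2)CCCC1` and compound 2 `CC(C)c1cccc(C(C)C)c1NC(=O)NCC1(c2ccc(N)cc2)CCCC1` share one core and differ in a single group. In an assay on microsomes for inhibition of acyl-CoA:cholesterol acyltransferase (Oryctolagus cuniculus) (a lower number here means a stronger inhibitor, a higher number a weaker inhibitor), compound 1 gives 63 nM, and compound 2 gives 29 nM, a step of a 2.2-fold lower number from compound 1 to compound 2 (0.34 log units; beyond the scatter). Within the data shown here, of the two numbers known, compound 2 holds the lower one. Compound 3 `CC(C)c1cccc(C(C)C)c1NC(=O)NCC1(c2ccc(NCCO)cc2)CCCC1` is built from compound 2 by 2-hydroxyethyl in place of hydrogen on a nitrogen on an aromatic ring. Among the measured compounds shown here, only one measured step exists, and it replaced the group on an aromatic carbon rather than anything on the nitrogen, so it bears on the new change only loosely. On that thin basis compound 3 is expected to land close to compound 2. In this assay the expected step is a 1.0-fold higher number from compound 2 to compound 3 (0.01 log units; within the scatter), which amounts to no change beyond the scatter. The estimate for compound 3 is 30 nM, within a range from 10 nM to 90 nM.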

Compound 3, half-maximal inhibitory concentration: 25 nM
Beside the measured number, compound 3's estimate is 1.2-fold (0.08 log units) above it; the measured number falls inside the stated range.
By their numbers in this assay, from the lowest: compounds 3 and 2 (each within the scatter of the next); then compound 1.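

This is the first change shown on the nitrogen itself, and in this assay 2-hydroxyethyl in place of hydrogen gives a 1.2-fold lower number from compound 2 to compound 3 (0.06 log units; within the scatter) so the two compounds cannot be told apart. This nitrogen therefore accepts the added chain without a detectable loss, and the difference from the tert-butyl compound remains, at a 2.5-fold lower number from compound 1 to compound 3 (0.40 log units; beyond the scatter) beyond the scatter as well. Nothing available explains why the number stays within the scatter when the chain is added.

On these data alone, whether the hydroxyl matters stays open, since an ethyl group on the same nitrogen would separate its contribution from that of the two-carbon chain. Also open, as far as these compounds go, is how far this tolerance extends, for example to a longer chain such as 3-hydroxypropyl, or to a chain ending in a carboxylic acid.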